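Stretching the ethyl group to 4-phenoxybutyl

The source may report more compounds than this note shows. Statements on the series, on what has been measured and on what is new or still open speak of the compounds shown alone.

compound 1 `Cc1ccc(-c2cnc(N(Cc3ccccc3)Cc3ccc(C(=O)NO)cc3)s2)cc1` gives 48800 nM
compound 2 `CCN(Cc1ccc(C(=O)NO)cc1)c1ncc(-c2ccc(C)cc2)s1` gives 6870 nM
compound 3 `CCCCCCCCN(Cc1ccc(C(=O)NO)cc1)c1ncc(-c2ccc(C)cc2)s1` gives 6500 nM

In a functional assay on HCT-116 cells (Homo sapiens) for antiproliferative activity, read by MTT assay, with a stated time of 48 h (a higher number here means a weaker inhibitor of growth, a lower number a stronger inhibitor of growth), compound 2 stands within the scatter of compound 3 and well under compound 1 on these numbers. Compound 4 `Cc1ccc(-c2cnc(N(CCCCOc3ccccc3)Cc3ccc(C(=O)NO)cc3)s2)cc1` is reached through 2-phenoxyethyl in place of hydrogen on a saturated chain carbon, two bonds along the chain from a nitrogen on an aromatic ring and so carries 4-phenoxybutyl where compound 2 has ethyl. Two comparisons bear on this. The long chain of compound 3 gives 6500 nM and a 1.1-fold lower number from compound 2 to compound 3 (0.02 log units; within the scatter) is the step. The phenyl-bearing group of compound 1 gives 48800 nM and a 7.1-fold lower number from compound 1 to compound 2 (0.85 log units; beyond the scatter) is the step. Chain length alone therefore suggests no step beyond the scatter, while the ring leans the expectation slightly upward. The expected step, a 1.3-fold higher number from compound 2 to compound 4 (0.12 log units; within the scatter) as estimated, stays small. For compound 4 the estimate is 9000 nM and 3000 nM to 30000 nM is the expected range.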

Compound 4, concentration for 50% growth inhibition: 680 nM
For compound 4 the middle estimate is 13-fold (1.12 log units) above the measured one, and the stated range ends above it.
By their numbers in this assay, from the lowest: compound 4; then compounds 3 and 2 (each within the scatter of the next); then compound 1.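

In this assay, the added length of compound 3 brought no change beyond the scatter, yet 4-phenoxybutyl brings a 10-fold lower number from compound 2 to compound 4 (1.00 log units; beyond the scatter), so this site responds to what the chain carries, not merely to its length. Phenoxy in place of butyl gives a 9.6-fold lower number from compound 3 to compound 4 (0.98 log units; beyond the scatter), and 3-phenoxypropyl in place of phenyl gives a 72-fold lower number from compound 1 to compound 4 (1.86 log units; beyond the scatter), so a phenyl ring in this group is compatible with the lowest number here when it is carried by the longer, oxygen-containing chain.

Still open, going by these compounds, is whether the gain needs the oxygen, which a 5-phenylpentyl chain would test, and whether a shorter 2-phenoxyethyl chain would do as well. Nothing measured here explains the gain.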